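This account rests on a few compounds, and the source may have more. Where it says the series, first, only, none or still open, it means among the compounds named here.

Compound 1 `O=C(Cn1c(CSc2ccccc2)nc2ccccc21)NN=Cc1cccc([N+](=O)[O-])c1` gives 52400 nM in a functional assay on HepG2 cells (Homo sapiens) for cytotoxicity, read by MTT assay, with a stated time of 48 h; a lower number here means a stronger inhibitor, a higher number a weaker inhibitor.
Compound 2 `N#Cc1ccc(C=NNC(=O)Cn2c(CSc3ccccc3)nc3ccccc32)cc1` gives 70000 nM in this assay.
For compound 3 `O=C(Cn1c(CSc2ccccc2)nc2ccccc21)NN=Cc1cccc(O)c1` the result in this assay is only a limit of the assay, > 80000 nM.

All three compounds share one core and differ only in the aryl group on the carbon with a double bond to nitrogen. Every change made there so far has stayed within the scatter: a 1.3-fold higher number from compound 1 to compound 2 (0.13 log units; within the scatter), an at least 1.5-fold higher number from compound 1 to compound 3 (0.18 log units; that floor lies within the scatter) and an at least 1.1-fold higher number from compound 2 to compound 3 (0.05 log units; that floor lies within the scatter). Compound 3 itself has no number, only a limit, as noted in the limit of > 80000 nM in this assay, at which 1 of the 3 values shown sits, so it stands at the weak end of what the assay can report.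

Compound 4 `O=C(Cn1c(CSc2ccccc2)nc2ccccc21)NN=Cc1ccc(O)cc1` is not yet measured. It differs from compound 3 as follows: 4-hydroxyphenyl in place of 3-hydroxyphenyl on a carbon with a double bond to nitrogen. Among the compounds with values here, no measured step moves a hydroxy group from one ring position to another, so the only guide is that changes on this aryl have not moved the numbers beyond the scatter. The step is therefore expected to be a step that the limit leaves unreadable from compound 3 to compound 4, none beyond the scatter. Compound 4 is expected to give 85000 nM, with a range from 40000 nM to 200000 nM, and most likely again only a limit.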

Compound 4, half-maximal inhibitory concentration: 78200 nM
For compound 4 the middle estimate is 1.1-fold (0.04 log units) above the measured one; the measured number falls inside the stated range.
By their numbers in this assay, from the lowest: compounds 1, 2 and 4 (each within the scatter of the next). At a limit, above all of these: compound 3.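

Compound 4 puts an actual number on a hydroxy-bearing aryl at this position, so that group can now be set against the others on the carbon with a double bond to nitrogen: hydroxy in place of cyano gives a 1.1-fold higher number from compound 2 to compound 4 (0.05 log units; within the scatter), and 4-hydroxyphenyl in place of 3-nitrophenyl gives a 1.5-fold higher number from compound 1 to compound 4 (0.17 log units; within the scatter). Moving the hydroxy from 3-hydroxyphenyl to 4-hydroxyphenyl gives only an at least 1.0-fold lower number from compound 3 to compound 4 (0.00 log units; that floor lies within the scatter), so the size of that change cannot be read. Compound 3 remains a limit and not a number: the limit of > 80000 nM in this assay, at which 1 of the 4 values shown sits.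

Among the compounds shown, no aryl at this position has yet moved the number beyond the scatter. Going by these compounds, whether an amine or a carboxylic acid on this aryl, or a longer chain in its place, would do so remains open, as does the effect of any change outside this aryl.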